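Replacing the aminomethyl chain of compound 3

The source may hold more compounds than are shown below. What is called first, only, known or untested is meant among the compounds shown, and "the series" means these compounds.

In a functional assay on the whole organism for antagonist activity, with Mus musculus as the target (a lower number here means that less compound is needed, a higher number that more compound is needed for the effect), compound 1 `CC(=O)NCC(=O)Nc1ccc(Cl)cc1C(=O)c1ccccc1` comes in at 37 mg/kg and compound 2 `NCC(=O)NCC(=O)Nc1ccc([N+](=O)[O-])cc1C(=O)c1ccccc1Cl` at 2.64 mg/kg while compound 3 `CC(NC(=O)CN)C(=O)N(C)c1ccc(Cl)cc1C(=O)c1ccccc1Cl` stands at 0.47 mg/kg as the lowest of the three numbers. Its gaps to the other two both lie beyond the usual scatter, so among these three it needs the least compound for the effect.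

The step to compound 4 `CCCC(=O)NCC(=O)N(C)c1ccc(Cl)cc1C(=O)c1ccccc1Cl` puts ((propylcarbonyl)amino)methyl in place of 1-(((aminomethyl)carbonyl)amino)ethyl on a carbonyl carbon and leaves the rest of compound 3 unchanged. The chain that enters no longer ends in the aminomethyl group.

Among the measured compounds shown here, no measured pair shows this change on its own, as the three compounds also differ in other places. Compound 2 and compound 3 both carry the aminomethyl end. For the measured compounds named here, the only measured compound without it is compound 1 at 37 mg/kg and that makes it a rough guide, nothing firmer.

On that basis, a rise beyond the scatter is expected in this assay, estimated as a 21-fold higher number from compound 3 to compound 4 (1.33 log units; beyond the scatter) towards more compound being needed. Compound 4 is estimated at 10 mg/kg with an expected range from 2.5 mg/kg to 40 mg/kg around that figure.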

Compound 4, dose for half-maximal effect: 0.98 mg/kg
Beside the measured number, compound 4's estimate is 10-fold (1.01 log units) above it; measured number below the stated range.
By their numbers in this assay, from the lowest: compound 3; then compound 4; then compound 2; then compound 1.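

Among the compounds shown here, the swap at this carbonyl carbon gives a 2.1-fold higher number from compound 3 to compound 4 (0.32 log units; beyond the scatter) in this assay and this is the first direct reading of a change at this position. The step is modest, though beyond the usual scatter, and compound 4 still gives a measured dose of 0.98 mg/kg without any aminomethyl end, so in this pair that end is not required for the effect. The data give no measured property that would explain why the step is this small.

The change also does more than remove the aminomethyl end: the 1-substituted ethyl becomes a methyl and the chain ends in propyl, so this one pair cannot say which of these differences produces the step. A chain that keeps the aminomethyl end on the unbranched methyl would separate them, while a longer alkyl chain such as pentyl or a chain ending in a carboxylic acid would show how much further this position can be varied before the dose needed climbs.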